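Amide substituent variation on the anilinopyrimidine series

The source may report more compounds than this note shows. Statements on the series, on what has been measured and on what is new or still open speak of the compounds shown alone.

Measured so far:
compound 1, `COc1cc(-n2cccc2C(=O)N2CCCCC2)ccc1Nc1ncc(Cl)c(Nc2ccccc2NS(C)(=O)=O)n1`: 630 nM
compound 2, `CCN1CCN(C(=O)c2cccn2-c2ccc(Nc3ncc(Cl)c(Nc4ccccc4NS(C)(=O)=O)n3)c(OC)c2)CC1`: 1130 nM
compound 3, `COc1cc(-n2cccc2C(=O)N2CCC(C)CC2)ccc1Nc1ncc(Cl)c(Nc2ccccc2NS(C)(=O)=O)n1`: 1050 nM

All three share the same core and differ only in the amine bound to the carbonyl carbon. In a functional assay on NCI-H2228 cells (Homo sapiens) for antiproliferative activity, read by MTT assay, with a stated time of 72 h (on this read-out lower numbers stand for stronger inhibition and higher numbers for weaker inhibition), compound 1 carries the lowest number of the three, yet the steps to its neighbours are small: a 1.8-fold higher number from compound 1 to compound 2 (0.25 log units; within the scatter) and a 1.7-fold higher number from compound 1 to compound 3 (0.22 log units; within the scatter), both within the scatter. Compounds 2 and 3 show nothing beyond the scatter between them either, a 1.1-fold lower number from compound 2 to compound 3 (0.03 log units; within the scatter). On these numbers the amide substituent has so far not moved the read-out in this assay by more than the usual scatter.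

Compound 4, `COc1cc(-n2cccc2C(=O)N(C)C)ccc1Nc1ncc(Cl)c(Nc2ccccc2NS(C)(=O)=O)n1`, is the next member. Relative to compound 1 the change is dimethylamino in place of piperidin-1-yl on a carbonyl carbon. The two steps that bear on this, from compound 1 to compound 2 and from compound 1 to compound 3, each also replaced or altered the amine on the carbonyl carbon and stayed within the scatter. A step of about the same size is therefore expected, with no direction claimed beyond the scatter, a 1.3-fold higher number from compound 1 to compound 4 (0.10 log units; within the scatter). Compound 4 is estimated at 800 nM in this assay, in the range 300 nM to 2200 nM.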

Compound 4, half-maximal inhibitory concentration: 54 nM
Compound 4: middle estimate off by 15-fold (1.17 log units), on the high side; measured number outside the range, below it.
By their numbers in this assay, from the lowest: compound 4; then compounds 1, 3 and 2 (each within the scatter of the next).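

The amine on the carbonyl carbon is not a silent position in this assay: the ring-bearing amines stayed within the scatter of one another, whereas dimethylamino gives large steps in all three comparisons (a 12-fold lower number from compound 1 to compound 4 (1.07 log units; beyond the scatter)) (a 19-fold lower number from compound 3 to compound 4 (1.29 log units; beyond the scatter)) (a 21-fold lower number from compound 2 to compound 4 (1.32 log units; beyond the scatter)). All three steps run the same way, so among these four compounds the divide lies between dimethylamino and the ring-bearing amines, not among the ring-bearing amines themselves. No measurement at hand accounts for this divide.

From the compounds shown here alone, it remains open whether the step goes with the loss of the ring or with the lower heavy-atom count, since dimethylamino differs from piperidin-1-yl in both. Pyrrolidin-1-yl, a smaller ring amine, and diethylamino, a longer open-chain amine, would help to separate these two readings.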